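Aryl sulfonate notes: chlorophenyl analogue of compound 1

The compounds below may be only part of what the source reports. "The series", "measured", "known", "first", "only" and "open" are said of these compounds alone.

Compound 1 `Cc1ccccc1OS(=O)(=O)c1ccc(N2CCN(C)C2=O)cc1` is the parent of this set. Among the compounds with values here, in a functional assay on HT-29 cells (Homo sapiens) for antiproliferative activity, read by sulforhodamine B assay, with a stated time of 48 h (on this read-out lower numbers stand for stronger inhibition and higher numbers for weaker inhibition), compound 1 gives 4800 nM, the only full number among the values shown. Compound 2 `CN1CCN(c2ccc(S(=O)(=O)Oc3ccc(F)cc3)cc2)C1=O` carries a 4-fluorophenyl on the oxygen instead of the 2-methylphenyl of compound 1. In this assay compound 2 reaches only a limit of the assay, > 100000 nM. Within the data shown here, the step of an at least 20-fold higher number from compound 1 to compound 2 (1.31 log units; beyond the scatter) is the single measured change that bears on the new compound, and with it (the limit of > 100000 nM in this assay, at which 1 of the 2 values shown sits), where compound 2 sits.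

Compound 3 `CN1CCN(c2ccc(S(=O)(=O)Oc3ccc(Cl)cc3)cc2)C1=O` differs from compound 1 by 4-chlorophenyl in place of 2-methylphenyl on an oxygen. Because of an at least 20-fold higher number from compound 1 to compound 2 (1.31 log units; beyond the scatter) a large rise in number is expected here as well, with a fair chance that this assay again reports only a limit. For compound 3 the expected step is a 13-fold higher number from compound 1 to compound 3 (1.10 log units; beyond the scatter). The estimate for compound 3 is 60000 nM, spanning 15000 nM to 200000 nM.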

Compound 3, half-maximal inhibitory concentration: 12000 nM
Estimate against measurement, compound 3: 5.0-fold (0.70 log units) above; measured number below the stated range.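

Removing the 2-methylphenyl from the oxygen does not by itself abolish activity in this assay, as the change to 4-chlorophenyl gives only a 2.5-fold higher number from compound 1 to compound 3 (0.40 log units; beyond the scatter). The halogen on the aromatic carbon also matters: chloro in place of fluoro gives an at least 8.3-fold lower number from compound 2 to compound 3 (0.92 log units; beyond the scatter). The value for compound 2 is a limit and not a number, so this second step is a bound and not an exact size: the limit of > 100000 nM in this assay, at which 1 of the 3 values shown sits.

The compounds shown leave open whether the group itself or its place on the ring sets these numbers, and a 2-chlorophenyl or a 4-methylphenyl on the same oxygen would separate the two. Also open, as far as these compounds go, is how a 4-bromophenyl, or a phenyl carrying an amine, would read in this assay.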